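Methyl for chloro at the ring position of compound 3

The compounds below may be only part of what the source reports. "The series", "measured", "known", "first", "only" and "open" are said of these compounds alone.

Compound 3 `CC(C)(C)OC(=O)N1CCC(CCOC(=O)N2CCc3cc(S(C)(=O)=O)cc(Cl)c32)CC1` gives the lowest number of the three measured compounds in a functional assay on CHO cells for agonist activity at Glucose-dependent insulinotropic receptor (Homo sapiens), read by a luciferase reporter and cAMP accumulation, with a stated time of 2 h (a higher number here means that more compound is needed for the effect, a lower number that less compound is needed), at 21 nM. The unsubstituted parent compound 1 `CC(C)(C)OC(=O)N1CCC(CCOC(=O)N2CCc3cc(S(C)(=O)=O)ccc32)CC1` gives 68 nM, and the fluoro analogue compound 2 `CC(C)(C)OC(=O)N1CCC(CCOC(=O)N2CCc3cc(S(C)(=O)=O)cc(F)c32)CC1` gives 25 nM. The step of a 3.2-fold lower number from compound 1 to compound 3 (0.51 log units; beyond the scatter) and the step of a 2.7-fold lower number from compound 1 to compound 2 (0.43 log units; beyond the scatter) both lie beyond the scatter, while the step of a 1.2-fold lower number from compound 2 to compound 3 (0.08 log units; within the scatter) lies within it; compound 3 and compound 2 are therefore not separated on this number.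

Compound 4 `Cc1cc(S(C)(=O)=O)cc2c1N(C(=O)OCCC1CCN(C(=O)OC(C)(C)C)CC1)CC2` carries the change (methyl in place of chloro on an aromatic carbon). The measured steps show that placing a small group at this carbon lowers the number relative to compound 1, and that fluoro and chloro are not distinguished from each other. Methyl, also a single heavy atom here, is expected to behave like the other two small groups, so the step of a 1.3-fold higher number from compound 3 to compound 4 (0.11 log units; within the scatter) is expected to stay within the scatter. Compound 4 is estimated at 27 nM, with a range from 11 nM to 65 nM.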

Compound 4, half-maximal effective concentration: 44 nM
Estimate against measurement, compound 4: 1.6-fold (0.21 log units) below; low and high end bracket the measured number.
By their numbers in this assay, from the lowest: compounds 3, 2, 4 and 1 (each within the scatter of the next, the first and the last beyond it).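

In this assay methyl does not simply match the two halogens at this carbon: a 2.1-fold higher number from compound 3 to compound 4 (0.32 log units; beyond the scatter) lies beyond the scatter, while a 1.8-fold higher number from compound 2 to compound 4 (0.25 log units; within the scatter) lies within it, so methyl is separated from chloro but not from fluoro. Unlike fluoro and chloro, methyl is not separated from hydrogen, as a 1.5-fold lower number from compound 1 to compound 4 (0.19 log units; within the scatter) also lies within the scatter, which shows that a single heavy atom at this carbon does not by itself separate a compound from compound 1. Nothing at hand bears on the reason for this difference between chloro and methyl.

From the compounds shown here alone, how a methoxy group, a nitrile or an amine at this carbon would compare with chloro remains open. Going by these compounds, whether these steps hold without the methylsulfonyl group also stays open.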